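Swapping the Acyl Group on the Ester of Compound 2

This account rests on a few compounds, and the source may have more. Where it says the series, first, only, none or still open, it means among the compounds named here.

Measured so far:
compound 1, `CC(C)=CC[C@@H](OC[C@@H](C)O)C1=CC(=O)c2c(O)ccc(O)c2C1=O`, in a functional assay on HeLa cells (Homo sapiens) for cytotoxicity, read by MTT assay (a lower number here means a stronger inhibitor, a higher number a weaker inhibitor), gives 22500 nM
compound 2, `CCCCC(O)CC(=O)O[C@H](CC=C(C)C)C1=CC(=O)c2c(O)ccc(O)c2C1=O`, gives 72200 nM
compound 3, `CCCC(CC(=O)O[C@H](CC=C(C)C)C1=CC(=O)c2c(O)ccc(O)c2C1=O)OC(C)=O`, gives 51200 nM

Among these three, compound 2 carries the highest number. Compound 3 is nearest to it, with a step of a 1.4-fold lower number from compound 2 to compound 3 (0.15 log units; within the scatter), so the two cannot be ordered. Compound 1 is furthest away, the step being a 3.2-fold higher number from compound 1 to compound 2 (0.51 log units; beyond the scatter).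

Compound 4, `CC(C)=CC[C@@H](OC(=O)C1CCCCO1)C1=CC(=O)c2c(O)ccc(O)c2C1=O`, has not been measured. It differs from compound 2 by oxan-2-yl in place of 2-hydroxyhexyl on a carbonyl carbon. Among the measured compounds shown here, two measured steps bear on this kind of change. Going from compound 1 to compound 2 replaced the whole group on the oxygen and gave a modest rise; going from compound 2 to compound 3 altered the acyl chain and stayed within the scatter. Both suggest that changes on the acyl side of this ester move the number little. Compound 4 is therefore expected to stay close to compound 2, with an expected step of a 1.2-fold lower number from compound 2 to compound 4 (0.10 log units; within the scatter), leaning slightly lower. The estimate for compound 4 is 58000 nM, expected between 22000 nM and 150000 nM.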

Compound 4, half-maximal inhibitory concentration: > 100000 nM
Compound 4: a limit, no number; the forecaster's own chance of this, stated with the estimate: 15%; middle value at least 1.7-fold (0.23 log units) away from the limit.
By their numbers in this assay, from the lowest: compound 1; then compounds 3 and 2 (each within the scatter of the next). At a limit, above all of these: compound 4.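

In this assay compound 4 gives a limit and not a number: the limit of > 100000 nM in this assay, at which 1 of the 4 values shown sits. The steps of an at least 1.3-fold higher number from compound 2 to compound 4 (0.14 log units; that floor lies within the scatter) and an at least 1.9-fold higher number from compound 3 to compound 4 (0.29 log units; that floor lies within the scatter) have floors within the scatter, so oxan-2-yl on this carbonyl carbon cannot yet be ordered against the open chains of compound 2 and compound 3. Among the compounds shown here, only the step of an at least 4.4-fold higher number from compound 1 to compound 4 (0.64 log units; beyond the scatter) clears the scatter, placing (oxan-2-yl)carbonyl on this oxygen clearly on the weaker side of 2-hydroxypropyl, which is the first sign that a ring here can be tolerated no better than that group.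

On these data alone, the true size of the change stays open, since a limit gives only a floor. Also open, as far as these compounds go, is whether an amine in this ring, or a carboxylic acid on the acyl chain, would bring the number down.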